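This account rests on a few compounds, and the source may have more. Where it says the series, first, only, none or still open, it means among the compounds named here.

In a functional assay on MDA-MB-231 cells (Homo sapiens) for cytotoxicity, read by MTT assay, with a stated time of 72 h (a higher number here means a weaker inhibitor, a lower number a stronger inhibitor), compound 3 `COc1cc(/C=C(\C)C(=O)N2CCC=C(Br)C2=O)cc(OC)c1OC` gives 2470 nM, the lowest of the three numbers recorded. Compound 1 `COc1cc(/C=C(\C)C(=O)N2CCC=CC2=O)cc(OC)c1OC` gives 11700 nM, and compound 2 `CCC/C(=C\c1cc(OC)c(OC)c(OC)c1)C(=O)N1CCC=C(Cl)C1=O` gives 8130 nM. Among the compounds with values here, the one single-point step known, a 4.7-fold lower number from compound 1 to compound 3 (0.68 log units; beyond the scatter), concerns the halogen on the ring and not the chain. Compound 4 `CCC/C(=C\c1cc(OC)c(OC)c(OC)c1)C(=O)N1CCC=C(Br)C1=O` differs from compound 3 by ethyl in place of hydrogen on a saturated chain carbon bound to a double-bonded chain carbon. Within the data shown here, no measured pair isolates this change: compound 2 carries the propyl chain but also chloro, so its value against compound 3 cannot be attributed to the chain alone. With nothing bearing on it directly, a step of no more than the scatter is expected, a 1.2-fold higher number from compound 3 to compound 4 (0.08 log units; within the scatter), and compound 4 is estimated at 3000 nM, in the range 1200 nM to 8000 nM.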

Compound 4, half-maximal inhibitory concentration: 2360 nM
Beside the measured number, compound 4's estimate is 1.3-fold (0.10 log units) above it; low and high end bracket the measured number.
By their numbers in this assay, from the lowest: compounds 4 and 3 (each within the scatter of the next); then compounds 2 and 1 (each within the scatter of the next).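

In this assay, ethyl in place of hydrogen on a saturated chain carbon bound to a double-bonded chain carbon gives a 1.0-fold lower number from compound 3 to compound 4 (0.02 log units; within the scatter) and so leaves the number unmoved across this methyl to propyl difference. With the propyl chain held fixed, bromo in place of chloro on a double-bonded ring carbon gives a 3.4-fold lower number from compound 2 to compound 4 (0.54 log units; beyond the scatter) as a step that isolates the halogen, which compound 2 alone could not do. No evidence here explains either step. From the compounds shown here alone, whether a longer chain, or a chain ending in an amine, would leave the number equally unmoved remains open. So does whether iodo on that ring carbon would extend the step seen for bromo.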